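Furan Regioisomers on a Dihydropyrimidinone Scaffold at the A3 Receptor

The source may report more compounds than this note shows. Statements on the series, on what has been measured and on what is new or still open speak of the compounds shown alone.

Measured compounds:
compound 1 `CC1=C(C(=O)OCC(C)C)C(c2ccoc2)NC(=O)N1`: 16%
compound 2 `CCCC(=O)C1=C(C)NC(=O)NC1c1ccoc1`: 2%
compound 3 `CC1=C(C(=O)OC2CCC2)C(c2ccco2)NC(=O)N1`: 1%

In an assay on membranes from HeLa cells for displacement of a labelled ligand from adenosine receptor A3 (Homo sapiens), read by scintillation counting, with a stated time of 180 min, tested at 1 uM (on this read-out lower numbers stand for less inhibition and higher numbers for more inhibition at the one concentration tested (going by the name of the read-out)), compound 3 gives 1%, the lowest of the three numbers; compound 2 with 2% sits within the scatter of it, while compound 1 with 16% lies beyond the scatter above it. Going by the values given here, the only measured step, a number 14 percentage points lower from compound 1 to compound 2 (beyond the scatter), concerns the group on the carbonyl carbon and not the furan, so it does not bear directly on the change at hand.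

Compound 4 `CC1=C(C(=O)OC2CCC2)C(c2ccoc2)NC(=O)N1` is the unmeasured analogue. Compared with compound 3 it shows (furan-3-yl in place of furan-2-yl on a saturated ring carbon). Among the compounds with values here, no measured pair isolates this change; compound 1 carries the furan-3-yl group but differs from compound 4 in another place, so it offers only a loose hint that furan-3-yl can go with a somewhat higher number.

Compound 4 is therefore expected to give 7%, with a plausible range from 0% to 20%, a step of a number 6 percentage points higher from compound 3 to compound 4 (within the scatter) that is not expected to exceed the scatter.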

Compound 4, a percentage reported as inhibition, at one concentration (the size of the read-out at that concentration, not a potency): 1%
For compound 4 the middle estimate is 6 percentage points above the measured one; measured number inside the range.
By their numbers in this assay, from the lowest: compounds 3, 4 and 2 (each within the scatter of the next); then compound 1.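

In this assay, going by these compounds alone, furan-3-yl in place of furan-2-yl on the saturated ring carbon, with cyclobutyloxy held on the carbonyl carbon, gives no change at the digits printed from compound 3 to compound 4 (within the scatter), so this pair isolates the furan change for the first time and shows no readable difference between the two furan groups. With furan-3-yl held, cyclobutyl in place of isobutyl on the oxygen gives a number 15 percentage points lower from compound 1 to compound 4 (beyond the scatter), whereas cyclobutyloxy in place of propyl on the carbonyl carbon gives a number 1 percentage points lower from compound 2 to compound 4 (within the scatter), so among these compounds only the isobutoxy group stands apart. Nothing available explains either the absent furan effect or the isobutyl to cyclobutyl step.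

The compounds shown leave open whether the two furan groups would also read alike with isobutoxy on the carbonyl carbon. Also open, on these data alone, is how a longer chain such as hexyloxy, or an amine, would read in that place.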